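A few compounds are considered here, and "the series" means these few. Any claim that something is new, unique, unknown or untested is made for them only; others in the source may bear on it.

Measured in an ADME assay on HepG2 2.2.15 cells (Homo sapiens) for cytotoxicity; on this read-out higher numbers stand for lower toxicity in this test and lower numbers for higher toxicity in this test:
- Compound 1 `CCOCC(=O)OCCc1c(-c2ccccc2Cl)c2cc(Cl)ccc2[nH]c1=O`: 130000 nM
- Compound 2 `CC(=O)N1CCC(C(=O)OCCc2c(-c3ccccc3Cl)c3cc(Cl)ccc3[nH]c2=O)CC1`: 82000 nM

Only these two compounds have been measured so far, and their values lie within the scatter of each other. Compound 2, at 82000 nM, therefore stands level with compound 1 on the numbers available.

The next compound, compound 3 `O=C(OCCc1c(-c2ccccc2Cl)c2cc(Cl)ccc2[nH]c1=O)c1cccnc1`, keeps the shared core and has pyridin-3-yl in place of 1-acetylpiperidin-4-yl on a carbonyl carbon.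

Among the measured compounds shown here, one measured step bears on this change, and it concerns the same carbonyl carbon. In a 1.6-fold lower number from compound 1 to compound 2 (0.20 log units; within the scatter), 1-acetylpiperidin-4-yl replaces ethoxymethyl, and that step stays within the scatter. For the measured compounds named here, no compound with an aromatic ring at this place has been measured yet, so the evidence is thin. Even so, no step beyond the scatter is expected in this assay. The estimate amounts to an expected 1.1-fold higher number from compound 2 to compound 3 (0.04 log units; within the scatter).

The estimate for compound 3 is an expected 90000 nM, with an expected range from 35000 nM to 180000 nM.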

Compound 3, half-maximal cytotoxic concentration: 170000 nM
Estimate against measurement, compound 3: 1.9-fold (0.28 log units) below; measured number inside the range.
By their numbers in this assay, from the lowest: compounds 2, 1 and 3 (each within the scatter of the next, the first and the last beyond it).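

In this assay, the group on this carbonyl carbon now produces its first step beyond the scatter: pyridin-3-yl in place of 1-acetylpiperidin-4-yl gives a modest change (a 2.1-fold higher number from compound 2 to compound 3 (0.32 log units; beyond the scatter)), in the direction of lower toxicity in this test. Among the compounds shown here, the same pyridin-3-yl group set against ethoxymethyl stays within the scatter (a 1.3-fold higher number from compound 1 to compound 3 (0.12 log units; within the scatter)), so an aromatic ring at this place does not separate compound 3 from compound 1, and only the pair of compound 2 and compound 3 stands apart, with compound 1 within the scatter of both. Nothing available on these compounds accounts for that modest difference.

On these data alone, it remains open whether a plain phenyl ring would read like compound 3, and whether a piperidin-4-yl group without its acetyl group would read like compound 2, so neither the ring nitrogen of pyridin-3-yl nor the acetyl group can be tied to the step. Also open, as far as these compounds go, is whether an amine or a carboxylic acid at the end of a longer chain on this carbonyl carbon would stay within the same narrow band of values.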